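Chloro-to-hydrogen swap on the amide aryl across two cores

The compounds below may be only part of what the source reports. "The series", "measured", "known", "first", "only" and "open" are said of these compounds alone.

Compound 1 `O=C1COc2ccc(-c3cccc(NS(=O)(=O)c4ccc(F)cc4)c3)cc2N1c1ccc(Cl)cc1` and compound 2 `O=C1COc2ccc(-c3cccc(NS(=O)(=O)c4ccc(F)cc4)c3)cc2N1c1ccccc1` share one core and differ by hydrogen in place of chloro on an aromatic carbon. In a functional assay on A-375 cells (Homo sapiens) for antiproliferative activity, read by MTT assay, with a stated time of 72 h (on this read-out lower numbers stand for stronger inhibition and higher numbers for weaker inhibition), compound 1 gives 32500 nM. Compound 2 gives only a limit in this assay, > 40000 nM. The measured step of an at least 1.2-fold higher number from compound 1 to compound 2 (0.09 log units; that floor lies within the scatter) is read against (the limit of > 40000 nM in this assay, at which 2 of the 3 values shown sit), so the floor of the step stays within the scatter and the change appears flat on this core.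

Compound 3 `O=C1COc2ccc(-c3cnc4ccccc4c3)cc2N1c1ccc(Cl)cc1` carries a second core; how it differs from compound 1 is not broken down here. Compound 3 gives only a limit in this assay, > 40000 nM. Within the data shown here, compound 4 `O=C1COc2ccc(-c3cnc4ccccc4c3)cc2N1c1ccccc1` is the unmeasured partner of compound 3 and differs from it by hydrogen in place of chloro on an aromatic carbon, the same change as the one from compound 1 to compound 2, at a place described in the same words.

The expectation rests on compound 3, whose result is the limit > 40000 nM. It also rests on the step of an at least 1.2-fold higher number from compound 1 to compound 2 (0.09 log units; that floor lies within the scatter), which lies within the scatter. The expected step is a step that the limit leaves unreadable from compound 3 to compound 4. Compound 4 is estimated at 45000 nM, most likely again a limit in this assay.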

Compound 4, half-maximal inhibitory concentration: > 40000 nM
Compound 4 gave a limit, no number; the forecaster's own chance of this, stated with the estimate: 85%; the middle value is on the limit's open side.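

In this assay compound 3 gives only a limit, > 40000 nM. Compound 4 also gives only a limit, > 40000 nM, so no step can be read between compound 3 and compound 4.

Left open is whether 4-chlorophenyl to phenyl changes activity on the core of compound 3, since the values shown mostly stop at one limit: the limit of > 40000 nM in this assay, at which 3 of the 4 values shown sit.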